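The source may report more compounds than this note shows. Statements on the series, on what has been measured and on what is new or still open speak of the compounds shown alone.

Measured in an ADME assay on HepG2 2.2.15 cells (Homo sapiens) for cytotoxicity, read by CCK-8 assay, with a stated time of 8 days; on this read-out higher numbers stand for lower toxicity in this test and lower numbers for higher toxicity in this test:
- compound 1 `COc1ccc(-c2cc(NC(=O)c3ccc(OC)cc3O)c[nH]c2=O)cc1`: 49900 nM
- compound 2 `COc1ccc(C(=O)Nc2c[nH]c(=O)c(-c3cccc(C)c3)c2)c(O)c1`: > 100000 nM (a limit of the assay, not a number)
- compound 3 `CCOc1ccc(-c2cc(NC(=O)c3ccc(OC)cc3O)c[nH]c2=O)cc1`: 69600 nM

The standing of compound 3 rests on one numeric comparison (a 1.4-fold higher number from compound 1 to compound 3 (0.14 log units; within the scatter)). Against compound 2 there is only a limit to compare with.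

Next is compound 4 `CCOc1ccc(-c2cc(NC(=O)c3cccc(OC)c3O)c[nH]c2=O)cc1`, which has the same atoms as compound 3, joined differently (2-hydroxy-3-methoxyphenyl in place of 2-hydroxy-4-methoxyphenyl on a carbonyl carbon). The methoxy group moves within the aromatic group on the carbonyl carbon, giving 2-hydroxy-3-methoxyphenyl in place of 2-hydroxy-4-methoxyphenyl.

Among the compounds with values here, none of the measured steps alters this group, so they bear only indirectly. The other two (an at least 2.0-fold higher number from compound 1 to compound 2 (0.30 log units; that floor lies within the scatter) and an at least 1.4-fold lower number from compound 2 to compound 3 (0.15 log units; that floor lies within the scatter)) also show no change beyond the scatter. Within the data shown here, the series so far therefore gives no ground for a real shift from compound 3 (69600 nM) in this assay.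

The expected step is small and within the scatter, with no firm direction (a 1.0-fold higher number from compound 3 to compound 4 (0.00 log units; within the scatter)). For compound 4 the estimated value is 70000 nM, with an expected range from 32000 nM to 100000 nM.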

Compound 4, half-maximal cytotoxic concentration: 34500 nM
For compound 4 the middle estimate is 2.0-fold (0.31 log units) above the measured one; measured number inside the range.
By their numbers in this assay, from the lowest: compounds 4, 1 and 3 (each within the scatter of the next). At a limit, above all of these: compound 2.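

Within the data shown here, this is the first change at the aromatic group on the carbonyl carbon, and in this assay moving the methoxy group gives a 2.0-fold lower number from compound 3 to compound 4 (0.30 log units; within the scatter). The step lies within the scatter, so 2-hydroxy-3-methoxyphenyl and 2-hydroxy-4-methoxyphenyl are not separated on this read-out, and this place accepts both arrangements without a change that can be called real. No measurement shown gives a reason for the step.

Open, on these data alone, is whether a different kind of group on this aromatic ring, such as an amine or a carboxylic acid in place of the methoxy group, would give a step beyond the scatter. Also open, as far as these compounds go, is whether the 2-hydroxy-3-methoxyphenyl group would behave the same way alongside the 3-methylphenyl group of compound 2.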